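Removing methoxycarbonyl from compound 1

The source may report more compounds than this note shows. Statements on the series, on what has been measured and on what is new or still open speak of the compounds shown alone.

Values so far in an ADME assay on J774 cells (Mus musculus) for cytotoxicity (on this read-out higher numbers stand for an effect only at larger amounts of compound and lower numbers for an effect already at smaller amounts), for the series:
- compound 1 `COC(=O)c1c[nH]c2cc(OCCOc3ccccc3)ccc2c1=O` gives > 20000 nM as a limit
- compound 2 `COC(=O)c1c[nH]c2cc(OCCOc3ccccc3)c(C)cc2c1=O` gives > 20000 nM as a limit
- compound 3 `COC(=O)c1c[nH]c2cc(OCCOc3ccccc3)c(Br)cc2c1=O` gives > 20000 nM as a limit

Compound 1 stands on a limit and not on a number. The series offers only the limit of > 20000 nM in this assay, at which 3 of the 3 values shown sit, as its footing.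

Compound 4 `O=c1cc[nH]c2cc(OCCOc3ccccc3)ccc12` differs from compound 1 in one change: hydrogen in place of methoxycarbonyl on an aromatic carbon in all.

The measured steps are a step that the two limits leave unreadable from compound 1 to compound 2 and a step that the two limits leave unreadable from compound 1 to compound 3 and a step that the two limits leave unreadable from compound 2 to compound 3 in the series. None removes methoxycarbonyl, so they give no size to carry over. No shift beyond the scatter is expected in this assay for this change, though a shift cannot be excluded. The expected change is a number no higher from compound 1 to compound 4 (the limit leaves the size open) on this estimate. Compound 4 is estimated at 20000 nM with a range from 8000 nM to 30000 nM as expected bounds.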

Compound 4, half-maximal effective concentration: > 20000 nM
Compound 4 was reported as a limit; the forecaster's own chance of this, stated with the estimate: 70%; the middle value lies on the limit itself.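

No step can be read between compound 1 and compound 4 in this assay, as both values are limits and not numbers. The compounds shown leave open whether hydrogen in place of methoxycarbonyl shifts this read-out at all.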